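Trading 4-fluorobenzyl for butyl in compound 4

The source may hold more compounds than are shown below. What is called first, only, known or untested is meant among the compounds shown, and "the series" means these compounds.

In an ADME assay on KB cells (Homo sapiens) for cytotoxicity (a higher number here means that more compound is needed for the effect, a lower number that less compound is needed), the measured compounds gave these values:
- Compound 1 `COC(=O)N1[C@@H]2C=C[C@@](OC)(C(=O)c3c2cc(OC)c(OC)c3OCc2ccc(F)cc2)N1C(=O)OC` gives 56.6 ug/mL
- Compound 2 `CCCOc1c(OC)c(OC)cc2c1C(=O)[C@]1(OC)C=C[C@H]2N(C(=O)OCC)N1C(=O)OCC` gives > 300 ug/mL as a limit of the assay
- Compound 3 `CCOC(=O)N1[C@@H]2C=C[C@@](OC)(C(=O)c3c2cc(OC)c(OC)c3OCc2ccccc2F)N1C(=O)OCC` gives 99.7 ug/mL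

Compound 1 at 56.6 ug/mL lies within the usual scatter of compound 3 at 99.7 ug/mL in this assay and has no number from compound 2 to compare. Compound 2 stands at > 300 ug/mL, which is a limit and not a number.

Compound 4 `CCCCOc1c(OC)c(OC)cc2c1C(=O)[C@]1(OC)C=C[C@H]2N(C(=O)OC)N1C(=O)OC` has not been measured. It carries propyl in place of 4-fluorophenyl on a saturated chain carbon bound to an oxygen on an aromatic ring. Within the data shown here, the one measured step that bears on this is an at least 3.0-fold lower number from compound 2 to compound 3 (0.47 log units; beyond the scatter), where 2-fluorophenyl replaces ethyl at that place. Compound 4 runs the same kind of exchange in reverse, so a higher number is expected, of modest size or more. The expected change is a 3.4-fold higher number from compound 1 to compound 4 (0.53 log units; beyond the scatter), and it rests on that single step. For compound 4 the estimated value is 190 ug/mL, with an expected range from 80 ug/mL to 450 ug/mL.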

Compound 4, concentration for half-maximal effect: > 300 ug/mL
Compound 4: only a limit was reported; the forecaster's own chance of this, stated with the estimate: 35%; at least 1.5-fold (0.19 log units) between middle value and limit.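

In this assay, propyl in place of 4-fluorophenyl on a saturated chain carbon bound to an oxygen on an aromatic ring gives an at least 5.3-fold higher number from compound 1 to compound 4 (0.72 log units; beyond the scatter) and so adds a second step at this place. It points the same way as an at least 3.0-fold lower number from compound 2 to compound 3 (0.47 log units; beyond the scatter) even though the groups exchanged differ, and across these two steps the fluorinated aromatic ring goes with the lower number. As far as these compounds go, compound 4 gives > 300 ug/mL as a limit and not a number, and the full size of the step stays unknown because of that limit: the limit of > 300 ug/mL in this assay, at which 2 of the 4 values shown sit.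

The compounds shown leave open whether the aromatic ring alone is enough, as a plain benzyl without fluorine would show. They also leave open whether a shorter chain such as methyl, or a chain ending in an amine, would bring the number within the measurable range.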